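The source may hold more compounds than are shown below. What is called first, only, known or untested is meant among the compounds shown, and "the series" means these compounds.

Of the compounds shown here, three sharing one core have been tested in a functional assay on ACHN cells (Homo sapiens) for inhibition, read by sulforhodamine B assay, with a stated time of 48 h, tested at 10 uM; on this read-out lower numbers stand for less inhibition and higher numbers for more inhibition at the one concentration tested (going by the name of the read-out). Compound 1 `Brc1cn2ccnc2c(-c2ccc3ncn(C4CCCCC4)c3c2)n1` gives 11.5% in this assay. Compound 2 `c1ccc(-c2cn3ccnc3c(-c3ccc4ncn(C5CCCCC5)c4c3)n2)cc1` gives 35.9% in this assay, and compound 3 `CC(=O)c1ccc(-c2cn3ccnc3c(-c3ccc4ncn(C5CCCCC5)c4c3)n2)cc1` gives 4.32% in this assay. Compound 3 thus holds the lowest of the three numbers: its gap to compound 1 lies within the usual scatter, while the step of a number 31.6 percentage points lower from compound 2 to compound 3 (beyond the scatter) lies beyond it. Compound 4 `Brc1ccc(-c2cn3ccnc3c(-c3ccc4ncn(C5CCCCC5)c4c3)n2)cc1` has not yet been measured. It differs from compound 3 in one place: bromo in place of acetyl on an aromatic carbon. The step of a number 31.6 percentage points lower from compound 2 to compound 3 (beyond the scatter) bears most directly on this change: there the acetyl group entered the same phenyl ring and inhibition fell sharply. Taking that acetyl group away again in compound 4 would, by that measure, be expected to undo much of the drop, although bromo now stands where hydrogen stood in compound 2, and no measured step tells what bromo does at that spot. The step of a number 24.4 percentage points higher from compound 1 to compound 2 (beyond the scatter) concerns a different place and adds less. Compound 4 is therefore expected to show more inhibition than compound 3, a step of roughly a number 20.7 percentage points higher from compound 3 to compound 4 (beyond the scatter) in this assay. The estimate for compound 4 is 25%, with a range from 5% to 50%.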

Compound 4, a percentage reported as inhibition, at one concentration (the size of the read-out at that concentration, not a potency): 21.4%
Beside the measured number, compound 4's estimate is 3.6 percentage points above it, and the stated range covers the measured number.
By their numbers in this assay, from the lowest: compounds 3, 1 and 4 (each within the scatter of the next, the first and the last beyond it); then compound 2.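

In this assay, bromo in place of acetyl on the phenyl ring gives a number 17.1 percentage points higher from compound 3 to compound 4 (beyond the scatter), so the low number of compound 3 does not follow from simply having any group at this carbon. Bromo still does not match plain hydrogen, with a number 14.5 percentage points lower from compound 2 to compound 4 (beyond the scatter), so both groups tested at this carbon give lower numbers than hydrogen, and they also differ from each other beyond the scatter. Against the core of compound 1, the change to 4-bromophenyl gives a number 9.9 percentage points higher from compound 1 to compound 4 (within the scatter), so adding this larger group in place of the bromo on the core makes no clear difference, unlike the plain phenyl of compound 2.

No measurement shown gives a reason for any of these steps. As far as these compounds go, it remains open whether an amine, a carboxylic acid or a methoxy group at this carbon would keep the number close to that of compound 2 or take it down towards that of compound 3, and with only hydrogen, bromo and acetyl compared, no trend across groups can yet be drawn.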